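Cytotoxicity limits in the series: removing isopropoxy

This account rests on a few compounds, and the source may have more. Where it says the series, first, only, none or still open, it means among the compounds named here.

compound 1 `COc1ccc(C2=C(c3cc(OC)c(OC)c(OC)c3)C(=O)C(OC(C)=O)C2)cc1OC(C)C`: > 100 ug/mL
compound 2 `COc1ccc(C2=C(c3cc(OC)c(OC)c(OC)c3)C(=O)CC2C)cc1C(=O)O`: > 100 ug/mL

In an ADME assay on ECV-304 cells (Homo sapiens) for cytotoxicity, read by MTT assay, with a stated time of 72 h (a lower number here means a stronger inhibitor, a higher number a weaker inhibitor), compound 1 gives > 100 ug/mL, which is a limit and not a number. Compound 2 gives > 100 ug/mL, also a limit. Compound 1 therefore stands at the limit of > 100 ug/mL in this assay, at which 2 of the 2 values shown sit.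

Compound 3 `COc1ccc(C2=C(c3cc(OC)c(OC)c(OC)c3)C(=O)C(OC(C)=O)C2)cc1` carries hydrogen in place of isopropoxy on an aromatic carbon. For the measured compounds named here, no measured step is available, and in this assay no change beyond the scatter is expected: a number no higher from compound 1 to compound 3 (the limit leaves the size open). This expectation rests on compound 1 at > 100 ug/mL, a limit. For compound 3 the estimated value is 100 ug/mL, with an expected range from 30 ug/mL to 300 ug/mL.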

Compound 3, half-maximal inhibitory concentration: 18 ug/mL
The estimate for compound 3 lay 5.6-fold (0.74 log units) above the measured number; the whole stated range lies above it.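

In this assay, hydrogen in place of isopropoxy on an aromatic carbon gives an at least 5.5-fold lower number from compound 1 to compound 3 (0.74 log units; beyond the scatter). For the compounds shown here, this carbon, ortho to a methoxy group, therefore matters for the read-out in this core, which the earlier compounds could not show. Of the compounds shown, only compound 3 gives a number rather than a limit: the limit of > 100 ug/mL in this assay, at which 2 of the 3 values shown sit.

On these data alone, the full size of the step stays open, since compound 1 gives only a limit. Also open, as far as these compounds go, is whether a hydroxyl or an amine on this carbon would read like isopropoxy or like hydrogen.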